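The compounds below may be only part of what the source reports. "The series", "measured", "known", "first", "only" and "open" are said of these compounds alone.

For the measured compounds named here, in a functional assay on Ramos cells (Homo sapiens) for antiproliferative activity (on this read-out higher numbers stand for weaker inhibition and lower numbers for stronger inhibition), compound 2 (`Nc1ncnc2c1c(-c1ccc(Oc3ccccc3)cc1)cn2[C@H]1CCN(C[C@@H]2CO2)C1`) gives 6710 nM, the higher and thus weaker of the two numbers so far, while compound 1 (`Nc1ncnc2c1c(-c1ccc(NC(=O)c3ccccc3)cc1)cn2[C@H]1CCN(C[C@@H]2CO2)C1`) gives 2250 nM. Compound 3 (`CC(C)(C)c1ccc(Oc2ccc(-c3cn([C@H]4CCN(C[C@@H]5CO5)C4)c4ncnc(N)c34)cc2)cc1`) adds one group to compound 2: tert-butyl in place of hydrogen on an aromatic carbon, a tert-butyl in place of hydrogen on an aromatic carbon, para to a large group. Going by the values given here, only one measured step bears on this, and only loosely: a 3.0-fold higher number from compound 1 to compound 2 (0.47 log units; beyond the scatter), a modest change of a different kind. Among the compounds with values here, with no measured example of this change, the expected result is a 1.1-fold lower number from compound 2 to compound 3 (0.05 log units; within the scatter), probably within the scatter. For compound 3, the estimated value is 6000 nM, with a range of 2200 nM to 18000 nM.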

Compound 3, half-maximal inhibitory concentration: 11200 nM
Compound 3: middle estimate off by 1.9-fold (0.27 log units), on the low side; the measured number falls inside the stated range.
By their numbers in this assay, from the lowest: compound 1; then compounds 2 and 3 (each within the scatter of the next).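

In this assay, the step of a 1.7-fold higher number from compound 2 to compound 3 (0.22 log units; within the scatter) shows that a tert-butyl can sit on this aromatic carbon, para to a large group, without a change that stands clear of the scatter. The step of a 5.0-fold higher number from compound 1 to compound 3 (0.70 log units; beyond the scatter) is a gap beyond the scatter, so 4-(tert-butyl)phenoxy, like phenoxy, does not match benzamido here. No available evidence accounts for either step. From the compounds shown here alone, whether an amine or a carboxylic acid on this same carbon would shift the number remains open, as does the effect of tert-butyl on the benzamido group of compound 1.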